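A few compounds are considered here, and "the series" means these few. Any claim that something is new, unique, unknown or untested is made for them only; others in the source may bear on it.

Compound 1 `CSc1nc(NCc2ccc(-c3ccccn3)cc2)c2[nH]nc(C(C)C)c2n1` has the highest number of the three compounds measured in a functional assay on G-361 cells (Homo sapiens) for cytotoxicity, read by fluorescence, with a stated time of 72 h; a lower number here means a stronger inhibitor, a higher number a weaker inhibitor: compound 1 gives 1400 nM. Compound 3 `CC(C)c1n[nH]c2c(NCc3ccc(-c4ccccn4)cc3)nc(N[C@H]3CC[C@H](N)CC3)nc12` gives 745 nM in this assay, and compound 2 `CC(C)c1n[nH]c2c(NCc3ccc(-c4ccccn4)cc3)nc(N3CCCCC3CCO)nc12` gives 204 nM in this assay. Between the latter two, the step of a 3.7-fold higher number from compound 2 to compound 3 (0.56 log units; beyond the scatter) is modest.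

Compound 4 `COc1ccc(CNc2nc(NCc3ccc(-c4ccccn4)cc3)c3[nH]nc(C(C)C)c3n2)cc1` differs from compound 1 in one place: (4-methoxybenzyl)amino in place of methylsulfanyl on an aromatic carbon. Going by the values given here, two measured steps bear on this change, since both also remove methylsulfanyl from compound 1 and attach a nitrogen-linked group to the same aromatic carbon. The step of a 6.9-fold lower number from compound 1 to compound 2 (0.84 log units; beyond the scatter) is modest, while the step of a 1.9-fold lower number from compound 1 to compound 3 (0.27 log units; within the scatter) lies within the scatter. Neither step raised the number, and the (4-methoxybenzyl)amino group, like the (4-aminocyclohexyl)amino group, is joined through a nitrogen bearing a hydrogen. Compound 4 is therefore expected to give a lower number in this assay, with an estimated step of a 3.1-fold lower number from compound 1 to compound 4 (0.49 log units; beyond the scatter) of modest size. The estimate for compound 4 in this assay is 450 nM, with a range from 150 nM to 1400 nM.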

Compound 4, half-maximal inhibitory concentration: 7490 nM
Estimate against measurement, compound 4: 17-fold (1.22 log units) below; measured number above the stated range.
By their numbers in this assay, from the lowest: compound 2; then compounds 3 and 1 (each within the scatter of the next); then compound 4.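

At this carbon between two ring nitrogen atoms, a nitrogen-linked group does not by itself lower the number in this assay, since (4-methoxybenzyl)amino gives a 5.4-fold higher number from compound 1 to compound 4 (0.73 log units; beyond the scatter), the only rise from compound 1 among the steps shown. What the nitrogen carries matters, as 4-methoxybenzyl in place of 4-aminocyclohexyl gives a 10-fold higher number from compound 3 to compound 4 (1.00 log units; beyond the scatter). Set against the 2-(2-hydroxyethyl)piperidin-1-yl group, the (4-methoxybenzyl)amino group gives a 37-fold higher number from compound 2 to compound 4 (1.56 log units; beyond the scatter), the widest gap seen at this position.

No available evidence accounts for this rise. The compounds shown leave open whether it belongs to the methoxy group or to the benzyl group itself, a question that a plain benzylamino group or a 4-aminobenzylamino group would help to separate.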